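Branched alkoxy chain in place of a cyclopentylethoxy chain

The source may hold more compounds than are shown below. What is called first, only, known or untested is meant among the compounds shown, and "the series" means these compounds.

Measured so far:
compound 1 `O=C(/C=C/c1ccc(O)cc1)c1c(O)cccc1OCCC1CCCC1` 3370 nM
compound 2 `CC(C)(C)CCOc1cccc(O)c1C(=O)CCc1ccc(O)cc1` > 30000 nM
compound 3 `CC(C)(C)CCOc1cccc(O)c1C(=O)/C=C/c1ccc(S(N)(=O)=O)cc1` 2950 nM

Of the compounds shown here, three have been tested in a functional assay on NCI-H23 cells (Homo sapiens) for antiproliferative activity, read by sulforhodamine B assay; on this read-out higher numbers stand for weaker inhibition of growth and lower numbers for stronger inhibition of growth. Compound 1 `O=C(/C=C/c1ccc(O)cc1)c1c(O)cccc1OCCC1CCCC1` gives 3370 nM. Compound 3 `CC(C)(C)CCOc1cccc(O)c1C(=O)/C=C/c1ccc(S(N)(=O)=O)cc1` gives 2950 nM, and the two numbers lie within the scatter of each other, so nothing separates them. Among the measured compounds shown here, compound 2 `CC(C)(C)CCOc1cccc(O)c1C(=O)CCc1ccc(O)cc1` returns only a limit, > 30000 nM, and no number; it is the one value that sits at the limit of > 30000 nM in this assay, at which 1 of the 3 values shown sits. Among the two numbers that are known, compound 1 holds the higher one.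

The next compound, compound 4 `CCC(CC)COc1cccc(O)c1C(=O)/C=C/c1ccc(O)cc1`, keeps the shared core of compound 1 and differs from it in one place: pentan-3-yl in place of cyclopentylmethyl on a saturated chain carbon bound to an oxygen on an aromatic ring. For the measured compounds named here, no measured pair shows a change of this kind, so there is no direct guide for its size. The step is expected to stay small, in either direction, and most likely not beyond the scatter, since both groups are saturated hydrocarbon chains of similar bulk. Compound 4 is therefore expected to give about 4000 nM, somewhere between 1500 nM and 12000 nM, which means an expected step of a 1.2-fold higher number from compound 1 to compound 4 (0.07 log units; within the scatter).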

Compound 4, concentration for 50% growth inhibition: 3210 nM
The estimate for compound 4 lay 1.2-fold (0.10 log units) above the measured number; the measured number falls inside the stated range.
By their numbers in this assay, from the lowest: compounds 3, 4 and 1 (each within the scatter of the next). At a limit, above all of these: compound 2.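

Among the compounds shown here, the exchange of cyclopentylmethyl for pentan-3-yl gives a 1.0-fold lower number from compound 1 to compound 4 (0.02 log units; within the scatter) in this assay, the first direct reading of a change at this position on the shared core. The five-membered ring of the 2-cyclopentylethoxy chain can therefore give way to the open, branched 2-ethylbutoxy chain with no change in the read-out beyond the scatter, though this rests on a single pair. Nothing at hand accounts for this result.

As far as these compounds go, what remains open is how far this position accepts anything other than a saturated hydrocarbon chain, such as a chain ending in an amine or a carboxylic acid. It is equally unclear whether a much longer chain, or a short one such as methoxy, would leave the number where it stands.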